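The source may report more compounds than this note shows. Statements on the series, on what has been measured and on what is new or still open speak of the compounds shown alone.

Compound 2 `C=CC(=O)N1CC[C@H](N2C(=O)N(c3ccccc3)Cc3cnc(Nc4ccccc4)nc32)C1` stands lowest of the two measured numbers. Going by the values given here, in a physicochemical assay for solubility, read by HPLC, in phosphate buffer, measured as thermodynamic solubility, with a stated time of 24 h, at pH 6.8 (on this read-out lower numbers stand for lower solubility and higher numbers for higher solubility), compound 2 gives 3.5 ug/mL, and its only neighbour, compound 1 `C=CC(=O)N1CC[C@H](N2C(=O)N(c3ccccc3)Cc3cnc(Nc4ccc(N5CCN(C)CC5)cc4)nc32)C1`, gives 976 ug/mL in this assay. The two differ in a single place, and that step, a 280-fold lower number from compound 1 to compound 2 (2.45 log units; beyond the scatter), is a large one.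

Compound 3 `C=CC(=O)N1CC[C@H](N2C(=O)N(c3ccccc3)Cc3cnc(Nc4ccc(C5CCN(C)CC5)cc4)nc32)C1` is built from compound 2 by a change in that same place: 1-methylpiperidin-4-yl in place of hydrogen on an aromatic carbon. Among the compounds with values here, the entering group is not the one that compound 1 carries, but it is a saturated ring of similar size bearing a methylated nitrogen and sits on the same aromatic carbon. Within the data shown here, the only measured step that bears on this change is the one from compound 1 to compound 2, which was far beyond the scatter, so the change is expected to move the solubility strongly upward rather than leave it unchanged.

Because the step from compound 1 to compound 2 was a 280-fold lower number from compound 1 to compound 2 (2.45 log units; beyond the scatter), a rise of roughly a 110-fold higher number from compound 2 to compound 3 (2.06 log units; beyond the scatter) is expected for compound 3, somewhat short of a full return. Compound 3 is therefore estimated at about 400 ug/mL, within a range from 80 ug/mL to 1500 ug/mL.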

Compound 3, solubility: 310 ug/mL
Compound 3: middle estimate off by 1.3-fold (0.11 log units), on the high side, and the stated range covers the measured number.
By their numbers in this assay, from the lowest: compound 2; then compound 3; then compound 1.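

In this assay, a second group at this place, on an aromatic carbon of a six-membered aromatic ring of carbon only and para to a large group, also gives a large step (an 89-fold higher number from compound 2 to compound 3 (1.95 log units; beyond the scatter)), so the high reading is not confined to the 4-methylpiperazin-1-yl group of compound 1. The direct exchange of the two ring groups gives a much smaller step (a 3.1-fold lower number from compound 1 to compound 3 (0.50 log units; beyond the scatter)), modest in size yet still beyond the scatter, which shows that the two groups are close but not interchangeable on this read-out. No accompanying measurement explains either step, so the numbers record what happens without showing the reason.

The compounds shown leave open how a morpholin-4-yl ring, a carboxylic acid or a short chain ending in a dimethylamino group would read at this place, and whether the methyl on the ring nitrogen of either group matters, as a piperidin-4-yl group would test. They also leave open how 1-methylpiperidin-4-yl would read on another carbon of the same aromatic ring.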